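A few compounds are considered here, and "the series" means these few. Any claim that something is new, unique, unknown or untested is made for them only; others in the source may bear on it.

Working notes on the series.

In an ADME assay on HepG2 cells (Homo sapiens) for cytotoxicity, read by MTT assay, with a stated time of 24 h (a higher number here means that more compound is tolerated, a lower number that less compound is tolerated), compound 1 `O=[N+]([O-])c1ccc(CN2CCN(S(=O)(=O)c3ccccc3)CC2)o1` reaches only the limit > 56000 nM, a limit of the assay and not a number. Compound 2 `Cc1ccc(S(=O)(=O)N2CCN(Cc3ccc([N+](=O)[O-])o3)CC2)cc1` likewise reaches only the limit > 54000 nM in this assay. Compound 3 `O=[N+]([O-])c1ccc(S(=O)(=O)N2CCN(Cc3ccc([N+](=O)[O-])o3)CC2)cc1` gives only the limit > 50000 nM in this assay. Compound 3 therefore stands at a limit, as do the two other values shown, which sit at the limit of > 50000 nM in this assay, at which 1 of the 3 values shown sits, the limit of > 54000 nM in this assay, at which 1 of the 3 values shown sits, and (the limit of > 56000 nM in this assay, at which 1 of the 3 values shown sits). The steps from compound 1 to compound 2 a step that the two limits leave unreadable from compound 1 to compound 2, from compound 1 to compound 3 a step that the two limits leave unreadable from compound 1 to compound 3 and from compound 2 to compound 3 a step that the two limits leave unreadable from compound 2 to compound 3 are all left unreadable by the limits.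

Compound 4 `O=[N+]([O-])c1ccc(CN2CCN(S(=O)(=O)c3ccc(F)cc3)CC2)o1` differs from compound 3 by fluoro in place of nitro on an aromatic carbon. The measured steps bear on it only in showing that changes at this position have so far stayed at the limit in this assay; the step from compound 3 to compound 4 a step that the limit leaves unreadable from compound 3 to compound 4 is therefore expected to be unreadable as well. For compound 4 in this assay the estimate is 55000 nM, within the range 25000 nM to 120000 nM, most likely again reported only as a limit.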

Compound 4, half-maximal cytotoxic concentration: > 54000 nM
Compound 4 ended at the assay's limit (the forecaster's own chance of this, stated with the estimate: 85%); the middle value lies beyond the limit too.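

Compound 4, like compound 1, compound 2 and compound 3, gives only a limit in this assay, so none of the steps to compound 4 can be read. The compounds shown leave open the concentration at which any of them becomes cytotoxic, and whether these ring substituents change it.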